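Replacing a thioether link with a methylene in compound 1

A few compounds are considered here, and "the series" means these few. Any claim that something is new, unique, unknown or untested is made for them only; others in the source may bear on it.

Compound 1 `Cn1c(SCC(=O)N2CCC[C@H]2C(=O)Nc2ccccc2-n2cccc2)nc2ccccc21` is the stronger of the two measured compounds in an assay on CHO cells for displacement of a labelled ligand from Orexin receptor type 2 (Homo sapiens) (on this read-out higher numbers stand for weaker inhibition and lower numbers for stronger inhibition), where compound 1 gives 0.3 nM. Within the data shown here, the only other measured compound, compound 2 `O=C(Nc1ccccc1)[C@@H]1CCCN1C(=O)CSc1nc2ccccc2[nH]1`, gives 560 nM in this assay, a higher number that lies well beyond the scatter; compound 2 differs from compound 1 in more than one place, so no single step can be read from that pair.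

Compound 3 `O=C(Nc1ccccc1-n1cccc1)[C@@H]1CCCN1C(=O)CCc1nc2ccccc2[nH]1` is not yet measured. It differs from compound 1 in one place: (1H-benzimidazol-2-yl)methyl in place of (1-methyl-1H-benzimidazol-2-yl)sulfanyl on a saturated chain carbon bound to a carbonyl carbon. Thus the sulfur link is replaced by a methylene and the methyl on the benzimidazole nitrogen is lost, while the rest of the shared core is kept. Among the measured compounds shown here, with no measured pair that isolates either part of this change, the direction rests on the two values shown: compound 1 stays the only reference, and compound 3 is expected to remain potent yet to give a somewhat higher number, the step from compound 1 to compound 3 estimated at a 13-fold higher number from compound 1 to compound 3 (1.12 log units; beyond the scatter). For compound 3 the estimated value in this assay is 4 nM, within a range from 0.6 nM to 30 nM.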

Compound 3, inhibition constant: 11 nM
Compound 3: the middle estimate sits 2.8-fold (0.44 log units) below what was measured, within the range that was stated.
By their numbers in this assay, from the lowest: compound 1; then compound 3; then compound 2.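

In this assay, the change on the saturated chain carbon bound to a carbonyl carbon costs potency without abolishing it: the step is a 37-fold higher number from compound 1 to compound 3 (1.56 log units; beyond the scatter), a large one, yet compound 3 still gives 11 nM. Sulfur is therefore not required at this place for strong inhibition, and (1H-benzimidazol-2-yl)methyl, which carries 1 hydrogen-bond donor where the group it replaces has 0, is tolerated there at a clear price. No measurement is available that accounts for the size of this loss.

From the compounds shown here alone, the step joins two changes, the sulfur link giving way to a methylene and the methyl on the benzimidazole nitrogen being lost, so the share of each in the loss remains open. Also open, going by these compounds, is how an oxygen link, an amine link or a longer chain at this place would compare with compound 1 in this assay, and whether a methyl on the benzimidazole nitrogen would bring the methylene-linked series closer to it.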